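Cyano in place of furan-2-yl on a shared core

This account rests on a few compounds, and the source may have more. Where it says the series, first, only, none or still open, it means among the compounds named here.

Measured compounds:
Compound 1 `Cc1cc(Sc2ccc(Cl)cc2)cn2c(CSCCc3ccccc3)cnc12` gives 20 ug/mL in an ADME assay on HEL cells (Homo sapiens) for cytotoxicity, with a stated time of 3 days; on this read-out lower numbers stand for higher toxicity in this test and higher numbers for lower toxicity in this test.
Compound 2 `Cc1cc(-c2ccco2)c2ncc(CSCCc3ccccc3)n2c1` gives 100 ug/mL in this assay.

Of the compounds shown here, two have been tested so far. Compound 2 stands at the higher of the two numbers in this assay, that is, the less toxic one; its nearest neighbour, compound 1, sits at a lower number, and that gap is beyond the usual scatter. Compound 3 `Cc1cc(C#N)c2ncc(CSCCc3ccccc3)n2c1` is not yet measured and differs from compound 2 in one place: cyano in place of furan-2-yl on an aromatic carbon. Within the data shown here, no step between measured compounds follows this change, so the size of the step in this assay cannot be read from the data. The two groups differ in size and ring count, but nothing measured here ties such a change to toxicity. Compound 3 is therefore expected to land close to compound 2, with a step of no change at the digits printed from compound 2 to compound 3 (within the scatter) that may well sit within the scatter. The estimate for compound 3 in this assay is 100 ug/mL, with a range from 40 ug/mL to 200 ug/mL.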

Compound 3, minimum cytotoxic concentration: >= 20 ug/mL
Compound 3: only a limit was reported; the forecaster's own chance of this, stated with the estimate: 40%; the middle value does not contradict the limit.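

In this assay compound 3 gives >= 20 ug/mL, which is a limit and not a number. Among these compounds, no step from compound 2 to compound 3 can therefore be read. The compounds shown leave open whether cyano in place of furan-2-yl on an aromatic carbon shifts this read-out at all.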